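Moving the Methyl Group on the Sulfonamide Aryl Ring

The source may hold more compounds than are shown below. What is called first, only, known or untested is meant among the compounds shown, and "the series" means these compounds.

In a functional assay on HeLa cells (Homo sapiens) for inhibition, read by CCK-8 assay, with a stated time of 72 h (a higher number here means a weaker inhibitor, a lower number a stronger inhibitor), compound 1 (`O=C(/C=C/c1cccnc1)NCCCCCCc1cccc(S(=O)(=O)Nc2ccccc2)c1`) gives 30.4 nM, compound 3 (`Cc1ccc(NS(=O)(=O)c2cccc(CCCCCCNC(=O)/C=C/c3cccnc3)c2)cc1`) gives 38.8 nM and compound 2 (`O=C(/C=C/c1cccnc1)NCCCCCCCc1cccc(S(=O)(=O)Nc2ccccc2)c1`) gives 598 nM. Compound 3 thus lies within the scatter of compound 1, while compound 2 reads well above both of them, beyond the scatter.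

Compound 4 (`Cc1ccccc1NS(=O)(=O)c1cccc(CCCCCCNC(=O)/C=C/c2cccnc2)c1`) is the next case, with 2-methylphenyl in place of 4-methylphenyl on a sulfonamide nitrogen. Within the data shown here, one measured step bears on this change, a 1.3-fold higher number from compound 1 to compound 3 (0.11 log units; within the scatter), and it stays within the scatter. Compound 2 differs elsewhere in the structure and says nothing about this change. Among the measured compounds shown here, no measured compound yet carries the 2-methylphenyl group, so the expectation rests on that single small step and remains loose.

An estimated step of a 1.3-fold higher number from compound 3 to compound 4 (0.11 log units; within the scatter) is expected, slightly upward and not beyond the scatter. For compound 4 the expected value is 50 nM, with an estimated range from 20 nM to 130 nM.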

Compound 4, half-maximal inhibitory concentration: 2.34 nM
Estimate against measurement, compound 4: 21-fold (1.33 log units) above; measured number outside the range, below it.
By their numbers in this assay, from the lowest: compound 4; then compounds 1 and 3 (each within the scatter of the next); then compound 2.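

In this assay the place of the methyl on the aryl ring proves decisive, with a 17-fold lower number from compound 3 to compound 4 (1.22 log units; beyond the scatter) on going from 4-methylphenyl to 2-methylphenyl, although the two compounds have the same atoms. The methyl had looked nearly silent, with a 1.3-fold higher number from compound 1 to compound 3 (0.11 log units; within the scatter) staying within the scatter, yet as 2-methylphenyl it brings a 13-fold lower number from compound 1 to compound 4 (1.11 log units; beyond the scatter) over the plain phenyl group, so the earlier small step holds only for 4-methylphenyl. Nothing at hand explains this difference.

Going by these compounds, whether the gain is particular to methyl or extends to other groups on the sulfonamide nitrogen, such as 2-ethylphenyl or 2-methoxyphenyl, stays open. Also open, on these data alone, is whether 2-methylphenyl would keep its low number on the longer chain of compound 2.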